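This account rests on a few compounds, and the source may have more. Where it says the series, first, only, none or still open, it means among the compounds named here.

Compound 1 `COc1c(N2CC(C)OC(C)C2)c(F)cc2c(=O)c(C(=O)O)cn(C3CC3)c12` and compound 3 `COc1c(N2CC(C)OC(C)C2)c(F)c([N+](=O)[O-])c2c(=O)c(C(=O)O)cn(C3CC3)c12` share one core. In an ADME assay on Vero cells (Chlorocebus sabaeus) for cytotoxicity, read by MTT assay, with a stated time of 72 h (a lower number here means a stronger inhibitor, a higher number a weaker inhibitor), compound 1 gives 160000 nM and compound 3 gives 144000 nM. The change between them is nitro in place of hydrogen on an aromatic carbon and it made a step of a 1.1-fold lower number from compound 1 to compound 3 (0.05 log units; within the scatter). Compound 2 `CCN(CC)C(=O)C1CCCN(c2c(F)cc3c(=O)c(C(=O)O)cn(C4CC4)c3c2OC)C1` is built on another core; the difference between the two cores is not broken down here. In this assay compound 2 gives 136000 nM. Compound 4 `CCN(CC)C(=O)C1CCCN(c2c(F)c([N+](=O)[O-])c3c(=O)c(C(=O)O)cn(C4CC4)c3c2OC)C1` has not been measured; it differs from compound 2 by nitro in place of hydrogen on an aromatic carbon. This is the same kind of change, though the surroundings differ: in compound 1 the place is meta to a 2,6-dimethylmorpholin-4-yl group, while in compound 2 it is meta to a large group. The earlier step stayed within the scatter, so a small step is expected here as well. The expected step is a 1.0-fold lower number from compound 2 to compound 4 (0.02 log units; within the scatter). Compound 4 is accordingly estimated at 130000 nM in this assay, with a likely range from 80000 nM to 210000 nM.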

Compound 4, half-maximal inhibitory concentration: 124000 nM
The estimate for compound 4 lay 1.0-fold (0.02 log units) above the measured number, and the stated range covers the measured number.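

Placing nitro where hydrogen stood gave a step of a 1.1-fold lower number from compound 2 to compound 4 (0.04 log units; within the scatter) in this assay. Set beside the earlier step, the change carries across these two cores with no visible difference: the same change on two cores in this assay, a 1.1-fold lower number (0.05 log units; within the scatter) from compound 1 to compound 3 and a 1.1-fold lower number (0.04 log units; within the scatter) from compound 2 to compound 4, 1.0-fold (0.01 log units) apart, within the scatter of two such steps Both steps lie within the scatter, so this shows only that nitro made no readable difference in this cytotoxicity read-out on either core; two pairs set no rule for the whole series and say nothing about any other assay.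

The compounds shown leave open what an amino group or a nitrile would do at this same place, ortho to a fluoro group. They also leave open whether the step stays this small with hydrogen in place of the methoxy group.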